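Compound 3 to compound 4: a ring swap

The source may hold more compounds than are shown below. What is called first, only, known or untested is meant among the compounds shown, and "the series" means these compounds.

Of the compounds shown here, three have been measured so far in an ADME assay on HeLa cells (Homo sapiens) for cytotoxicity, read by MTT assay (on this read-out higher numbers stand for weaker inhibition and lower numbers for stronger inhibition), and their numbers lie close together. Compound 1 (`COc1ccc(C[C@H]2COC(=O)[C@@H]2Cc2ccc(OCc3cn(Cc4ccc(Cl)cc4)nn3)c(OC)c2)cc1OC`) reads 242000 nM and compound 2 (`CCN(CC)C(=O)CCC(=O)Oc1ccc(C[C@H]2C(=O)OC[C@@H]2Cc2ccc(OC)c(OC)c2)cc1OC`) reads 213000 nM while compound 3 (`CCN1CCN(C(=O)CCC(=O)Oc2ccc(C[C@H]3C(=O)OC[C@@H]3Cc3ccc(OC)c(OC)c3)cc2OC)CC1`) reads 190000 nM and so stands within the scatter of both.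

Compound 4 (`COc1ccc(C[C@H]2COC(=O)[C@@H]2Cc2ccc(OC(=O)CCC(=O)N3CCCCC3)c(OC)c2)cc1OC`) has not been measured yet. It differs from compound 3 on a carbonyl carbon, where piperidin-1-yl sits in place of 4-ethylpiperazin-1-yl (piperidin-1-yl in place of 4-ethylpiperazin-1-yl on a carbonyl carbon).

For the measured compounds named here, the one measured step at this same place is a 1.1-fold lower number from compound 2 to compound 3 (0.05 log units; within the scatter) and it came from 4-ethylpiperazin-1-yl replacing diethylamino. That single step is thin evidence, but it gives no reason to expect a large move, so no change beyond the scatter is expected in this assay for the new ring, in either direction. The expected outcome is a 1.1-fold higher number from compound 3 to compound 4 (0.02 log units; within the scatter) for this swap.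

Compound 4 is estimated at 200000 nM with an expected range of 120000 nM to 320000 nM for a single measurement.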

Compound 4, half-maximal inhibitory concentration: 128000 nM
For compound 4 the middle estimate is 1.6-fold (0.19 log units) above the measured one; the range from low to high includes it.
By their numbers in this assay, from the lowest: compounds 4, 3, 2 and 1 (each within the scatter of the next).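

In this assay, replacing 4-ethylpiperazin-1-yl on the carbonyl carbon gives a 1.5-fold lower number from compound 3 to compound 4 (0.17 log units; within the scatter), and piperidin-1-yl in place of diethylamino gives a 1.7-fold lower number from compound 2 to compound 4 (0.22 log units; within the scatter). Three different amine groups have now been compared at this one place, open-chain and ring, with one ring nitrogen or two, and every step among them stays within the scatter, so this position has not yet shown a real effect on the read-out. No other data shown here bear on this result.

On these data alone, it remains open whether a group of another kind on this carbonyl carbon, such as a morpholin-4-yl ring or a carboxylic acid, would move the number beyond the scatter. As far as these compounds go, whether a longer saturated chain carrying this carbonyl would do so is also open.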